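The source may report more compounds than this note shows. Statements on the series, on what has been measured and on what is new or still open speak of the compounds shown alone.

Measured compounds:
compound 1 `O=C(/C=C/c1ccc(Cl)cc1)Nc1ccc2ncnc(Nc3cccc(Cl)c3)c2c1`: 9.97 ug/mL
compound 2 `O=C(/C=C/c1ccccc1Cl)Nc1ccc2ncnc(Nc3cccc(Cl)c3)c2c1`: 1.74 ug/mL
compound 3 `COc1cccc(/C=C/C(=O)Nc2ccc3ncnc(Nc4cccc(Cl)c4)c3c2)c1`: 1.05 ug/mL

In a functional assay on B16-F10 cells (Mus musculus) for inhibition, read by MTT assay, with a stated time of 48 h (on this read-out lower numbers stand for stronger inhibition and higher numbers for weaker inhibition), compound 3 gives the lowest of the three numbers shown, although the step from compound 2 a 1.7-fold lower number from compound 2 to compound 3 (0.22 log units; within the scatter) stays within the scatter, while the step from compound 1 a 9.5-fold lower number from compound 1 to compound 3 (0.98 log units; beyond the scatter) lies beyond it. Compound 4 `O=C(/C=C/c1cccs1)Nc1ccc2ncnc(Nc3cccc(Cl)c3)c2c1` differs from compound 3 by thiophen-2-yl in place of 3-methoxyphenyl on a double-bonded chain carbon bound to a double-bonded chain carbon. All three measured steps change the aryl group at this same place: a 5.7-fold lower number from compound 1 to compound 2 (0.76 log units; beyond the scatter) and a 9.5-fold lower number from compound 1 to compound 3 (0.98 log units; beyond the scatter) were modest, and a 1.7-fold lower number from compound 2 to compound 3 (0.22 log units; within the scatter) was within the scatter. None of them exchanges the six-membered ring for a five-membered one, so the comparison is indirect. A small rise in number, near the edge of the scatter, is expected for compound 4, giving a 1.9-fold higher number from compound 3 to compound 4 (0.28 log units; within the scatter) and an estimate of 2 ug/mL with a range from 0.7 ug/mL to 6 ug/mL in this assay.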

Compound 4, half-maximal inhibitory concentration: 4.26 ug/mL
Estimate against measurement, compound 4: 2.1-fold (0.33 log units) below, and the stated range covers the measured number.
By their numbers in this assay, from the lowest: compounds 3 and 2 (each within the scatter of the next); then compound 4; then compound 1.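

In this assay the thiophen-2-yl group, the only five-membered ring at this place, falls inside the spread of the substituted phenyl groups, with a 4.1-fold higher number from compound 3 to compound 4 (0.61 log units; beyond the scatter) and a 2.4-fold higher number from compound 2 to compound 4 (0.39 log units; beyond the scatter) but a 2.3-fold lower number from compound 1 to compound 4 (0.37 log units; beyond the scatter). A six-membered aromatic ring is therefore not needed to stay below compound 1, though this five-membered ring does not reach compound 2 or compound 3. Nothing shown explains these differences. Still open, going by these compounds, is how a furan-2-yl or thiophen-3-yl group would compare at this place. On these data alone, an amine or a carboxylic acid on the ring also remains open.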